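This account rests on a few compounds, and the source may have more. Where it says the series, first, only, none or still open, it means among the compounds named here.

Measured compounds in the series:

compound 1, `COC(=O)c1nc(-c2ccsc2)n(-c2ccc(F)cc2)n1`, a functional assay on NCI-H226 cells (Homo sapiens) for inhibition, read by MTT assay, with a stated time of 72 h; a lower number here means a stronger inhibitor of growth, a higher number a weaker inhibitor of growth: 6940 nM
compound 2, `COC(=O)c1nc(-c2ccc[nH]2)n(-c2ccc(F)cc2)n1`, this assay: 72000 nM
compound 3, `COC(=O)c1nc(-c2ccsc2)n(-c2ccc(C(F)(F)F)cc2)n1`, this assay: 5740 nM

Two changes are seen among these. From compound 1 to compound 2 the change is 1H-pyrrol-2-yl in place of thiophen-3-yl on an aromatic carbon, and it gives a 10-fold higher number from compound 1 to compound 2 (1.02 log units; beyond the scatter). From compound 1 to compound 3 the change is trifluoromethyl in place of fluoro on an aromatic carbon, which gives a 1.2-fold lower number from compound 1 to compound 3 (0.08 log units; within the scatter); compound 1 and compound 3 are thus within the scatter of each other, and the cores of compound 3 and compound 4 differ from those of compound 1 and compound 2 in this one place only.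

Compound 4, `COC(=O)c1nc(-c2ccc[nH]2)n(-c2ccc(C(F)(F)F)cc2)n1`, has not yet been measured. It differs from compound 3 by 1H-pyrrol-2-yl in place of thiophen-3-yl on an aromatic carbon. This is the same kind of change as that from compound 1 to compound 2, though not the same: there the altered ring carbon stands next to the ring atom that bears a 4-fluorophenyl group (7 heavy atoms), here next to the ring atom that bears a large group. Among the measured compounds shown here, the only precedent is the step in this assay a 10-fold higher number from compound 1 to compound 2 (1.02 log units; beyond the scatter), and the step from compound 3 to compound 4 is expected to be of similar size, a 9.9-fold higher number from compound 3 to compound 4 (1.00 log units; beyond the scatter). For the measured compounds named here, on that basis compound 4 is estimated at 57000 nM, with a range of 25000 nM to 130000 nM, resting on the single prior step and on compound 3 at 5740 nM.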

Compound 4, concentration for 50% growth inhibition: 5650 nM
The estimate for compound 4 lay 10-fold (1.00 log units) above the measured number; the measured number lies below the stated range.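

In this assay, 1H-pyrrol-2-yl in place of thiophen-3-yl gives a 1.0-fold lower number from compound 3 to compound 4 (0.01 log units; within the scatter), so the large step seen on the core of compound 1 does not carry over to the core of compound 3: the same change on two cores in this assay, a 10-fold higher number (1.02 log units; beyond the scatter) from compound 1 to compound 2 and a 1.0-fold lower number (0.01 log units; within the scatter) from compound 3 to compound 4, 11-fold (1.02 log units) apart, beyond the scatter of two such steps. Trifluoromethyl in place of fluoro gives a 13-fold lower number from compound 2 to compound 4 (1.11 log units; beyond the scatter), so this change also depends on the core: the same change on two cores in this assay, a 1.2-fold lower number (0.08 log units; within the scatter) from compound 1 to compound 3 and a 13-fold lower number (1.11 log units; beyond the scatter) from compound 2 to compound 4, 11-fold (1.02 log units) apart, beyond the scatter of two such steps. The two changes therefore do not act independently across these four compounds, and a step measured on one core is a poor guide to the same step on the other, though the data do not show why, and a single set of four cannot show how general this is.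

On these data alone, it remains open whether the step from thiophen-3-yl to 1H-pyrrol-2-yl stays as small with chloro or methoxy in place of trifluoromethyl. As far as these compounds go, it also remains open whether the same dependence on the core holds with a carboxylic acid or a primary amide in place of the methoxycarbonyl group.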